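Swapping a selenol for methylsulfanyl on a fused core

The compounds below may be only part of what the source reports. "The series", "measured", "known", "first", "only" and "open" are said of these compounds alone.

Compound 1 `[SeH]c1nc(NCc2ccccc2)c2cccnc2n1` gives 68900 nM in a functional assay on CCRF-CEM cells (Homo sapiens) for cytotoxicity, read by MTT assay, with a stated time of 72 h; a lower number here means a stronger inhibitor of growth, a higher number a weaker inhibitor of growth.
Compound 2 `Nc1nc([SeH])nc2ncccc12` gives 61500 nM in this assay.
Compound 3 `COc1ccc(CNc2nc(SC)nc3ccccc23)cc1` gives > 100000 nM in this assay, which is a limit.

Of the two numbers that are numbers, compound 1 and compound 2 lie within the usual scatter of each other, so nothing separates them. The result for compound 3 is a limit of the assay and not a number, as the line the limit of > 100000 nM in this assay, at which 1 of the 3 values shown sits, states. Within the data shown here, no two of these measured compounds differ in only one place, so no measured step exists among them.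

Compound 4 `CSc1nc(NCc2ccccc2)c2cccnc2n1` differs from compound 1 by a group of 2 heavy atoms (1 carbon, 1 sulfur; no ring) in place of one selenium atom, on an aromatic carbon. Compound 3 also carries a methylsulfanyl group, though on another core and with a different amine, and its result in this assay is a limit. With nothing closer to lean on, a step beyond the scatter toward a higher number is expected, and a fair chance that only a limit is returned. Compound 4 is estimated at 110000 nM, with a range from 50000 nM to 250000 nM, which means an expected step of a 1.6-fold higher number from compound 1 to compound 4 (0.20 log units; within the scatter).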

Compound 4, concentration for total growth inhibition: 98600 nM
Compound 4: the middle estimate sits 1.1-fold (0.05 log units) above what was measured, and the stated range covers the measured number.
By their numbers in this assay, from the lowest: compounds 2, 1 and 4 (each within the scatter of the next). At a limit, above all of these: compound 3.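

Among these compounds, the first measured step at this position, on an aromatic carbon between two ring nitrogen atoms, shows that methylsulfanyl in place of the selenium atom leaves the result in this assay within the scatter: a 1.4-fold higher number from compound 1 to compound 4 (0.16 log units; within the scatter). Among the compounds shown here, on this shared core, therefore, the change separates compound 4 from compound 1 by nothing that can be read, and compound 4 still returns a number and not a limit, which the earlier compounds could not show. Compound 3, which also carries methylsulfanyl but differs in more than one place, remains the only compound with a limit, and that limit is not a number: the limit of > 100000 nM in this assay, at which 1 of the 4 values shown sits.

The compounds shown leave open whether any group at this position moves the number beyond the scatter, for example an amine, a carboxylic acid or a longer chain such as ethylsulfanyl. They also give no reason why the two groups read alike, and they do not tell whether the same swap would read alike on compound 2, which carries an unsubstituted amine in place of the benzylamine of compound 1.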